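Chloro on the thiazole phenyl across two cores

The compounds below may be only part of what the source reports. "The series", "measured", "known", "first", "only" and "open" are said of these compounds alone.

Measured so far:
compound 1 `COc1ccc(-c2nc(SCC(=O)c3sc(-c4ccccc4)nc3C)[nH]c(=O)c2C#N)cc1OC` 21.4%
compound 2 `COc1ccc(-c2nc(SCC(=O)c3sc(-c4ccc(Cl)cc4)nc3C)[nH]c(=O)c2C#N)cc1OC` 59.8%
compound 3 `Cc1nc(-c2ccccc2)sc1C(=O)CSc1nc(-c2ccc(Cl)cc2)c(C#N)c(=O)[nH]1` 63.4%

The values come from a functional assay on U-87MG ATCC cells for antiproliferative activity against U-87 MG (Homo sapiens), read by MTT assay, with a stated time of 48 h, tested at 50 uM; on this read-out higher numbers stand for a weaker effect at the one concentration tested and lower numbers for a stronger effect. Compound 2 differs from compound 1 by chloro in place of hydrogen on an aromatic carbon; this step gives a number 38.4 percentage points higher from compound 1 to compound 2 (beyond the scatter). Compound 3 differs from compound 1 in the core by 4-chlorophenyl in place of 3,4-dimethoxyphenyl on an aromatic carbon, with a number 42 percentage points higher from compound 1 to compound 3 (beyond the scatter). Compound 2 and compound 3 lie within the scatter of one another.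

Compound 4 `Cc1nc(-c2ccc(Cl)cc2)sc1C(=O)CSc1nc(-c2ccc(Cl)cc2)c(C#N)c(=O)[nH]1` is not yet measured; it differs from compound 3 by chloro in place of hydrogen on an aromatic carbon. The place is the same word for word as for compound 1 to compound 2, so this is the same change, now on the core of compound 3. Because a number 38.4 percentage points higher from compound 1 to compound 2 (beyond the scatter) was large and compound 3 already gives 63.4%, the step in this assay is expected to be smaller, a number 10.6 percentage points higher from compound 3 to compound 4 (beyond the scatter). Compound 4 is estimated at 74%, expected between 56% and 90%.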

Compound 4, a percentage reported as activity, at one concentration (the size of the read-out at that concentration, not a potency): 60%
Estimate against measurement, compound 4: 14 percentage points above, within the range that was stated.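

The step for chloro in place of hydrogen on the core of compound 3 in this assay is a number 3.4 percentage points lower from compound 3 to compound 4 (within the scatter), so this change does not carry over unchanged from the core of compound 1: the same change on two cores in this assay, a number 38.4 percentage points higher (beyond the scatter) from compound 1 to compound 2 and a number 3.4 percentage points lower (within the scatter) from compound 3 to compound 4, 41.8 percentage points apart, beyond the scatter of two such steps

The change from 3,4-dimethoxyphenyl to 4-chlorophenyl shows the same picture, with a number 0.2 percentage points higher from compound 2 to compound 4 (within the scatter), so the two changes do not add up across these four compounds: the same change on two cores in this assay, a number 42 percentage points higher (beyond the scatter) from compound 1 to compound 3 and a number 0.2 percentage points higher (within the scatter) from compound 2 to compound 4, 41.8 percentage points apart, beyond the scatter of two such steps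

This rests on one pair per core at a single concentration and does not show how either change would behave on any further core.

Open, on these data alone, is whether an amine or a carboxylic acid in place of the chloro would separate the two cores. Also open is how the effect of these compounds would compare at any other concentration, as only a single concentration is shown.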